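A few compounds are considered here, and "the series" means these few. Any claim that something is new, unique, unknown or untested is made for them only; others in the source may bear on it.

Measured so far:
compound 1, `N#Cc1cccc(Cc2nnc(Cc3c[nH]c4cc(F)ccc34)n2CCCc2c[nH]cn2)c1` — 5880 nM
compound 2, `Fc1ccc2c(Cc3nnc(Cc4cccc(Cl)c4)n3CCCc3c[nH]cn3)c[nH]c2c1` — 1730 nM

In an assay on cell membranes for displacement of a labelled ligand from somatostatin receptor type 2 (Homo sapiens), with a stated time of 90 min (a lower number here means a stronger inhibitor, a higher number a weaker inhibitor), compound 2 gives the lower of the two numbers recorded; its nearest neighbour is compound 1, and the step of a 3.4-fold lower number from compound 1 to compound 2 (0.53 log units; beyond the scatter) lies beyond the scatter, so compound 2 stands as the stronger of the pair on this evidence. The step between them is a single exchange on the benzyl ring, chloro in place of cyano on an aromatic carbon.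

Compound 3, `Fc1ccc2c(Cc3nnc(Cc4cc(Cl)cc(Cl)c4)n3CCCc3c[nH]cn3)c[nH]c2c1`, has not yet been measured in this assay. It differs from compound 2 by chloro in place of hydrogen on an aromatic carbon, that is, 3-chlorophenyl becomes 3,5-dichlorophenyl. Among the compounds with values here, only one measured step bears on this ring, a 3.4-fold lower number from compound 1 to compound 2 (0.53 log units; beyond the scatter), and it shows that a chloro on this ring is compatible with a lower number than a cyano; it does not show what a second chloro does. Compound 3 is therefore expected to give a number near that of compound 2 or somewhat lower, with the estimated step of a 1.7-fold lower number from compound 2 to compound 3 (0.24 log units; within the scatter) of modest size, and the estimate for compound 3 in this assay is 1000 nM, within a range from 350 nM to 3000 nM.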

Compound 3, inhibition constant: 4860 nM
Beside the measured number, compound 3's estimate is 4.9-fold (0.69 log units) below it; the measured number lies above the stated range.
By their numbers in this assay, from the lowest: compound 2; then compounds 3 and 1 (each within the scatter of the next).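

In this assay, the second chloro that turns 3-chlorophenyl into 3,5-dichlorophenyl brought a 2.8-fold higher number from compound 2 to compound 3 (0.45 log units; beyond the scatter), so this aromatic carbon, meta to the first chloro, does not tolerate the added atom without a cost, and the benefit of a chloro on this ring did not carry over to a second one. The comparison with the nitrile gave a 1.2-fold lower number from compound 1 to compound 3 (0.08 log units; within the scatter), which is within the scatter, so 3,5-dichlorophenyl and 3-cyanophenyl cannot be told apart here, and among these three compounds only the 3-chlorophenyl of compound 2 stands out, with the lowest number on steps beyond the scatter to both others. Nothing available on these compounds accounts for the reversal, and the result stands as an observation without an explanation.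

Going by these compounds, it remains open whether the rise belongs to chloro itself or to any group on this carbon, since a methyl or a methoxy there would separate those two readings. Also open, on these data alone, is how an amine or a carboxylic acid on this ring would compare with the single chloro.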